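The source may report more compounds than this note shows. Statements on the series, on what has been measured and on what is new or still open speak of the compounds shown alone.

Measured so far in a functional assay on the whole organism with Rattus norvegicus as the target; on this read-out lower numbers stand for an effect already at smaller amounts and higher numbers for an effect only at larger amounts of compound:
- compound 1 `Oc1nc(-c2ccccc2)ncc1-c1nn[nH]n1`: 100 mg/kg
- compound 2 `CCCOc1ccccc1-c1ncc(-c2nn[nH]n2)c(O)n1`: 0.04 mg/kg
- compound 3 `CCCCCOc1ccccc1-c1ncc(-c2nn[nH]n2)c(O)n1`: 0.4 mg/kg

Compound 2, at 0.04 mg/kg, has the lowest number of the three, and compound 3 is its nearest neighbour. The next compound to examine is compound 4 `CCCOc1ccc([N+](=O)[O-])cc1-c1ncc(-c2nn[nH]n2)c(O)n1`. It keeps everything in compound 2 but has nitro in place of hydrogen on an aromatic carbon, para to a propoxy group and meta to a large group (nitro in place of hydrogen on an aromatic carbon).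

Going by the values given here, three measured steps bear on this change, though none involves nitro. Substitution on an aromatic carbon gave large changes, with a 2500-fold lower number from compound 1 to compound 2 (3.40 log units; beyond the scatter) and a 250-fold lower number from compound 1 to compound 3 (2.40 log units; beyond the scatter). Changing the substituent's chain gave a modest step, with a 10-fold higher number from compound 2 to compound 3 (1.00 log units; beyond the scatter). These steps show that this assay responds strongly to changes in this part of the series, so a step beyond the scatter cannot be ruled out. Their direction cannot be carried over to nitro, however. Since compound 2 already has the lowest number, a small move upward is the more likely outcome, and the expected step is a 2.5-fold higher number from compound 2 to compound 4 (0.40 log units; beyond the scatter). For compound 4 the estimated value is 0.1 mg/kg, with an expected range from 0.01 mg/kg to 1 mg/kg.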

Compound 4, dose for 50% inhibition: 5 mg/kg
Beside the measured number, compound 4's estimate is 50-fold (1.70 log units) below it, and the stated range ends below it.
By their numbers in this assay, from the lowest: compound 2; then compound 3; then compound 4; then compound 1.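

In this assay, the earlier substitutions on this aromatic ring had only lowered the number, as in a 2500-fold lower number from compound 1 to compound 2 (3.40 log units; beyond the scatter), so a further hydrogen replaced on the ring might have been expected to cost little. Nitro in place of hydrogen on the carbon para to the propoxy group instead gives a 130-fold higher number from compound 2 to compound 4 (2.10 log units; beyond the scatter), which shows that this position is far from indifferent and that substitution on this ring can also raise the number sharply. This step also exceeds a 10-fold higher number from compound 2 to compound 3 (1.00 log units; beyond the scatter), so in this small set, adding nitro to the ring moves the number further than lengthening the chain from propoxy to pentyloxy, and no measurement at hand accounts for the size of the step.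

The compounds shown leave open whether the rise belongs to nitro itself or to any group at this carbon, a question that an amine, a methoxy group or a fluorine atom at the same place would address. They also leave open whether nitro at another carbon of this ring, or alongside pentyloxy rather than propoxy, would give a step of similar size.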